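Benzyloxycarbonyl for Methyl, Tested on a Second Core

The source may report more compounds than this note shows. Statements on the series, on what has been measured and on what is new or still open speak of the compounds shown alone.

Of the compounds shown here, three have been measured in a functional assay on HeLa cells (Homo sapiens) for antiproliferative activity, read by MTT assay, with a stated time of 48 h; on this read-out higher numbers stand for weaker inhibition and lower numbers for stronger inhibition. Compound 1 `Cc1ccc2[nH]c(-c3cn(-c4ccccc4)nc3-c3ccc(F)cc3)nc2c1` gives 3630 nM. Compound 2 `O=C(OCc1ccccc1)c1ccc2[nH]c(-c3cn(-c4ccccc4)nc3-c3ccc(F)cc3)nc2c1` gives 23600 nM, and compound 3 `Cc1ccc2[nH]c(-c3cn(-c4ccccc4)nc3-c3ccc(Cl)cc3)nc2c1` gives 5360 nM.

Two changes link them. From compound 1 to compound 2 the difference is benzyloxycarbonyl in place of methyl on an aromatic carbon, and it gave a 6.5-fold higher number from compound 1 to compound 2 (0.81 log units; beyond the scatter). From compound 1 to compound 3 the difference is chloro in place of fluoro on an aromatic carbon, and it gave a 1.5-fold higher number from compound 1 to compound 3 (0.17 log units; within the scatter), so compound 1 and compound 3 cannot be told apart on this read-out.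

Compound 4 `O=C(OCc1ccccc1)c1ccc2[nH]c(-c3cn(-c4ccccc4)nc3-c3ccc(Cl)cc3)nc2c1` has not yet been measured in this assay. It differs from compound 3 by benzyloxycarbonyl in place of methyl on an aromatic carbon. This is the same change that turns compound 1 into compound 2, made at the same place, but on the core of compound 3 instead of the core of compound 1; the two cores differ only by chloro in place of fluoro on an aromatic carbon.

Compound 4 is therefore expected to give a higher number than compound 3 in this assay because a 6.5-fold higher number from compound 1 to compound 2 (0.81 log units; beyond the scatter) was seen when the same change was made on the core of compound 1. The expected step is a 6.2-fold higher number from compound 3 to compound 4 (0.79 log units; beyond the scatter). Compound 4 is estimated at 33000 nM, with a range from 12000 nM to 90000 nM; whether the second core carries the change in the same way as the first is what the measurement will show.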

Compound 4, half-maximal inhibitory concentration: 8130 nM
Beside the measured number, compound 4's estimate is 4.1-fold (0.61 log units) above it; measured number below the stated range.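

On the core of compound 3, benzyloxycarbonyl in place of methyl gave a 1.5-fold higher number from compound 3 to compound 4 (0.18 log units; within the scatter), so the step seen on the core of compound 1 did not carry over in size, and the two steps differ: the same change on two cores in this assay, a 6.5-fold higher number (0.81 log units; beyond the scatter) from compound 1 to compound 2 and a 1.5-fold higher number (0.18 log units; within the scatter) from compound 3 to compound 4, 4.3-fold (0.63 log units) apart, beyond the scatter of two such steps

Read the other way, chloro in place of fluoro made no distinction between the methyl compounds but gave a 2.9-fold lower number from compound 2 to compound 4 (0.46 log units; beyond the scatter) among the benzyloxycarbonyl compounds, and this pair of steps differs as well: the same change on two cores in this assay, a 1.5-fold higher number (0.17 log units; within the scatter) from compound 1 to compound 3 and a 2.9-fold lower number (0.46 log units; beyond the scatter) from compound 2 to compound 4, 4.3-fold (0.63 log units) apart, beyond the scatter of two such steps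

Within these four compounds, then, the two changes do not add independently, and a step measured on one core was a poor guide to the same step on the other; this does not show why they interact, and a single pair of cores supports no rule for the wider series.

The compounds shown leave open whether the dependence on the halogen extends to bromo, or to a plain phenyl with no halogen at all, in the place of the fluoro and chloro groups. They also leave open whether a carboxylic acid or a methyl ester in place of benzyloxycarbonyl would behave differently on the two cores.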